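Removing the thiazole ring from a weak angiotensin receptor ligand

The source may report more compounds than this note shows. Statements on the series, on what has been measured and on what is new or still open speak of the compounds shown alone.

Compound 1 has the structure `CC[C@H](C)[C@H](NC(=O)c1cccc(Cn2ccnc2)c1)C(=O)Nc1nccs1`. In an assay on HEK293 cells for displacement of a labelled ligand from Type-2 angiotensin II receptor (Homo sapiens), tested at 1 uM (a higher number here means a stronger effect of the compound at the concentration tested, a lower number a weaker effect), compound 1 gives 4%, a result that sits within the usual scatter of a reading of zero, so compound 1 shows no clear effect. Two related compounds offer no number to compare against: compound 2, with the structure `CCCCNC(=O)[C@@H](NC(=O)c1cccc(Cn2ccnc2)c1)[C@@H](C)CC`, is reported in this assay as "not active" (no number reported), and compound 3, with the structure `CCCCS(=O)(=O)NNC(=O)[C@@H](NC(=O)c1cccc(Cn2ccnc2)c1)[C@@H](C)CC`, is reported as "not determined" (no result reported). Among the compounds with values here, compound 1 therefore stands alone as the only compound with a measured figure, and that figure is small.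

Compound 4 has the structure `CC[C@H](C)[C@H](NC(=O)c1cccc(Cn2ccnc2)c1)C(N)=O`. It differs from compound 1 in one place: hydrogen in place of 1,3-thiazol-2-yl on an amide-type nitrogen. Since compound 1 shows no effect to begin with, there is little room for a drop, and nothing among these compounds suggests that the change would bring a gain. The step from compound 1 to compound 4 is expected to be none beyond the scatter, namely a number 1 percentage points lower from compound 1 to compound 4 (within the scatter). For compound 4 in this assay the expected reading is 3%, within a range from -8% to 15%.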

Compound 4, a percentage reported as inhibition, at one concentration (the size of the read-out at that concentration, not a potency): "not active" (no number reported)
For compound 4 the study gives words and no number; no gap can be computed for the estimate.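

In this assay, within the data shown here, compound 4 is reported only in words, as not active, so no step from compound 1 to compound 4 can be read, and no measured evidence bears on this result.
What the compounds shown leave open is whether any change to the shared core gives a clear effect.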